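Swapping a Pyrrole for a Methoxyphenyl on the Alkene

The compounds below may be only part of what the source reports. "The series", "measured", "known", "first", "only" and "open" are said of these compounds alone.

Three compounds share a core in which a double-bonded chain carbon carries an aryl group, while the neighbouring chain carbon bears a sulfur-linked tolyl group and a chlorophenyl carbonyl. They were tested in a functional assay on DU-145 cells (Homo sapiens) for inhibition, read by trypan blue exclusion, with a stated time of 96 h; on this read-out lower numbers stand for stronger inhibition of growth and higher numbers for weaker inhibition of growth. Compound 1 `COc1ccc(/C=C(/Sc2ccc(C)cc2)C(=O)c2ccc(Cl)cc2)cc1O` gives 1000 nM. Compound 2 `Cc1ccc(S/C(=C/c2ccc(-c3ccccc3)cc2)C(=O)c2ccc(Cl)cc2)cc1` gives 50000 nM. Compound 3 `Cc1ccc(S/C(=C/c2ccc[nH]2)C(=O)c2ccc(Cl)cc2)cc1` gives 10000 nM, which places it second highest of the three numbers, nearer to compound 2 than to compound 1.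

The next compound, compound 4 `COc1ccc(/C=C(/Sc2ccc(C)cc2)C(=O)c2ccc(Cl)cc2)cc1`, has not yet been measured. It differs from compound 3 in one place: 4-methoxyphenyl in place of 1H-pyrrol-2-yl on a double-bonded chain carbon bound to a double-bonded chain carbon. Within the data shown here, the one measured step that speaks to this change is a 10-fold higher number from compound 1 to compound 3 (1.00 log units; beyond the scatter), where the pyrrole arrived in place of a hydroxylated methoxyphenyl and the number rose. Going back to a methoxyphenyl, now without the hydroxyl, should reverse much of that rise, so in this assay a clearly lower number is expected for compound 4, though not necessarily all the way to compound 1, since the hydroxyl is missing and compound 2 shows that a larger six-membered aryl alone does not guarantee a low number. The expected step is a 5.0-fold lower number from compound 3 to compound 4 (0.70 log units; beyond the scatter). Compound 4 is therefore estimated at 2000 nM, within 700 nM to 6000 nM.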

Compound 4, concentration for 50% growth inhibition: 1000 nM
Compound 4: the middle estimate sits 2.0-fold (0.30 log units) above what was measured, within the range that was stated.
By their numbers in this assay, from the lowest: compounds 1 and 4 (each within the scatter of the next); then compound 3; then compound 2.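

In this assay the move away from the pyrrole gives a 10-fold lower number from compound 3 to compound 4 (1.00 log units; beyond the scatter), so the 4-methoxyphenyl group on this double-bonded chain carbon does not need a hydroxy group to hold a low number. The earlier step from compound 1 to compound 3 changed the hydroxy group and the ring together, whereas hydrogen in place of hydroxy on an aromatic carbon isolates that one change and gives no change at the digits printed from compound 1 to compound 4 (within the scatter). The group on the six-membered ring can still count for a great deal, since methoxy in place of phenyl on an aromatic carbon gives a 50-fold lower number from compound 2 to compound 4 (1.70 log units; beyond the scatter), the largest step among these compounds.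

Nothing measured here explains any of these steps. Going by these compounds, it remains open how an ethoxy group, a dimethylamino group or a fluorine in place of the methoxy would fare, and whether a thiophene or a furan in place of 1H-pyrrol-2-yl would give a number closer to that of compound 3 or to that of compound 4.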